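From nitro to a fluorinated sulfur group on an inactive scaffold

This account rests on a few compounds, and the source may have more. Where it says the series, first, only, none or still open, it means among the compounds named here.

Compound 3 `O=[N+]([O-])c1cccc(Nc2cccc3onc(O)c23)c1` is the starting point of this comparison. In an ADME assay on isolated protein for inhibition of cytochrome c oxidase subunit 2 (Homo sapiens), read by ELISA (a higher number here means a weaker inhibitor, a lower number a stronger inhibitor), compound 3 gives > 100000 nM, which is a limit of the assay rather than a number. Compound 1 `Oc1noc2cccc(Nc3cccc(C(F)(F)F)c3)c12` gives > 100000 nM in this assay, again only a limit. Compound 2 `Oc1noc2ccc(Nc3cccc(C(F)(F)F)c3)cc12` gives > 100000 nM in this assay, likewise a limit. All three values therefore sit at the limit of > 100000 nM in this assay, at which 3 of the 3 values shown sit, and compound 3 stands at that limit together with the other two, with nothing to set it apart.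

The only measured step among these compounds, a step that the two limits leave unreadable from compound 1 to compound 3, cannot be read in size, since both of its ends are limits. Compound 4 `Oc1noc2cccc(Nc3cccc(S(F)(F)(F)(F)F)c3)c12` has not yet been measured in this assay. It differs from compound 3 by a group of 6 heavy atoms (5 fluorine, 1 sulfur; no ring) in place of a group of 3 heavy atoms (1 nitrogen, 2 oxygen; no ring), on an aromatic carbon. Among the compounds with values here, the one measured step on the same aromatic carbon, a step that the two limits leave unreadable from compound 1 to compound 3, offers no readable size and so no direction. Within the data shown here, no compound in this set has left the limit in this assay, so no step beyond the scatter is expected here either. Compound 4 is expected at 150000 nM, with a range from 50000 nM to 500000 nM. The expected step that the limit leaves unreadable from compound 3 to compound 4 is estimated to stay within the scatter, and a limit is the most likely report.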

Compound 4, half-maximal inhibitory concentration: > 100000 nM
Compound 4: no number, only a limit (the forecaster's own chance of this, stated with the estimate: 85%); the middle value lies beyond the limit too.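

Compound 4 gives only a limit in this assay, like compound 1 and compound 3, so the steps from those two compounds to compound 4 cannot be read in size: the limit of > 100000 nM in this assay, at which 4 of the 4 values shown sit.

The compounds shown leave open what change, if any, would bring a readable value in this assay, and how nitro, trifluoromethyl and the fluorinated sulfur group would rank.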